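A few compounds are considered here, and "the series" means these few. Any claim that something is new, unique, unknown or untested is made for them only; others in the source may bear on it.

Measured in a functional assay on HEK293 cells for agonist activity at Bile acid receptor (Homo sapiens), read by a luciferase reporter; on this read-out higher numbers stand for an effect only at larger amounts of compound and lower numbers for an effect already at smaller amounts:
- compound 1 `CC(C)c1onc(-c2c(Cl)cccc2Cl)c1COc1ccc(N(C)C(=O)c2ccc(C(=O)O)cc2)c(C(F)(F)F)n1` gives 208 nM
- compound 2 `CC(C)c1onc(-c2c(Cl)cccc2Cl)c1COc1ccc(NC(=O)c2ccc(C(=O)O)cc2)c(C(F)(F)F)n1` gives 385 nM
- compound 3 `CC(Nc1ccc(C(=O)O)cc1)c1ccc(OCc2c(-c3c(Cl)cccc3Cl)noc2C2CC2)nc1C(F)(F)F` gives 202 nM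

Compound 4 `CC(c1ccc(OCc2c(-c3c(Cl)cccc3Cl)noc2C2CC2)nc1C(F)(F)F)N(C)c1ccc(C(=O)O)cc1` has not yet been measured. It differs from compound 3 by methyl in place of hydrogen on a nitrogen on an aromatic ring. The same kind of change has already been made once in the series, from compound 2 to compound 1, as methyl in place of hydrogen on an amide-type nitrogen, and there it gave a 1.9-fold lower number from compound 2 to compound 1 (0.27 log units; within the scatter). The places are not the same: in the earlier pair the nitrogen is amide-type, with a carbonyl carbon as its other neighbour, whereas in compound 3 it sits on an aromatic ring with a saturated chain carbon as its other neighbour, so this is the same kind of change rather than the same change. How the core of compound 3 differs from that of compound 2 is not broken down here.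

For compound 4 the step from compound 3 is expected to be a 1.3-fold lower number from compound 3 to compound 4 (0.13 log units; within the scatter), resting on the earlier step of a 1.9-fold lower number from compound 2 to compound 1 (0.27 log units; within the scatter) and on compound 3 at 202 nM. Compound 4 is therefore estimated at 150 nM, expected between 60 nM and 450 nM.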

Compound 4, half-maximal effective concentration: 182 nM
Compound 4: middle estimate off by 1.2-fold (0.08 log units), on the low side, within the range that was stated.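

In this assay the methyl on a nitrogen on an aromatic ring gives a 1.1-fold lower number from compound 3 to compound 4 (0.05 log units; within the scatter) on this core. Set beside the methyl on the amide-type nitrogen of the earlier pair, the two steps do not separate: the same change on two cores in this assay, a 1.9-fold lower number (0.27 log units; within the scatter) from compound 2 to compound 1 and a 1.1-fold lower number (0.05 log units; within the scatter) from compound 3 to compound 4, 1.7-fold (0.22 log units) apart, within the scatter of two such steps. On both cores the change therefore leaves the read-out within the scatter, but two pairs with different kinds of nitrogen do not show that a fixed step carries from one core to another, nor do they resolve any real effect of the methyl.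

As far as these compounds go, whether an ethyl or a longer chain on this nitrogen stays within the scatter remains open. So does whether the methyl step holds with a primary amide in place of the carboxylic acid.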